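Benzyl carbamate replacing acyloxymethyl carbamate on a shared core

The source may report more compounds than this note shows. Statements on the series, on what has been measured and on what is new or still open speak of the compounds shown alone.

Compound 1 `CC(C)COC(=O)N1CCN(C(=O)c2nc(Nc3cc(C4CC4)[nH]n3)c3cc(Cl)ccc3n2)C[C@H]1C`: 46.9%
Compound 2 `CC(C)C(=O)OCOC(=O)N1CCN(C(=O)c2nc(Nc3cc(C4CC4)[nH]n3)c3cc(Cl)ccc3n2)C[C@H]1C`: 86.9%
Compound 3 `CC(OC(=O)N1CCN(C(=O)c2nc(Nc3cc(C4CC4)[nH]n3)c3cc(Cl)ccc3n2)C[C@H]1C)OC(=O)C(C)(C)C`: 65.3%

Three measured compounds share one core and differ only in the group on the oxygen next to the carbonyl of a carbamate. In an assay for inhibition of serine/threonine-protein kinase PAK 4 (Homo sapiens), read by FRET and Z'-LYTE, with a stated time of 60 min, tested at 50 uM, in the presence of a further agent that is not named here (a lower number here means a weaker effect, a higher number a stronger effect of the compound at the concentration tested), compound 2 gives the highest of the three numbers, ahead of compound 3 by a number 21.6 percentage points lower from compound 2 to compound 3 (beyond the scatter) and ahead of compound 1 by a number 40 percentage points higher from compound 1 to compound 2 (beyond the scatter) in the other direction, both beyond the scatter.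

Compound 4 `C[C@@H]1CN(C(=O)c2nc(Nc3cc(C4CC4)[nH]n3)c3cc(Cl)ccc3n2)CCN1C(=O)OCc1ccccc1` has not been measured. It differs from compound 2 in one place: phenyl in place of (isopropylcarbonyl)oxy on a saturated chain carbon bound to an oxygen next to a carbonyl group

Among the measured compounds shown here, two measured steps bear on this. Removing the (isopropylcarbonyl)oxy group, as in compound 1, cost a number 40 percentage points higher from compound 1 to compound 2 (beyond the scatter) read backwards, and exchanging it for a different ester, as in compound 3, gave a number 21.6 percentage points lower from compound 2 to compound 3 (beyond the scatter). A phenyl carries neither of the two hydrogen-bond acceptors counted in the leaving group, so compound 4 is expected to sit nearer compound 1 than compound 2, a step of a number 36.9 percentage points lower from compound 2 to compound 4 (beyond the scatter) downward.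

Compound 4 is therefore estimated at 50%, within 30% to 75%.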

Compound 4, a percentage reported as inhibition, at one concentration (the size of the read-out at that concentration, not a potency): 96%
Estimate against measurement, compound 4: 46 percentage points below; the whole stated range lies below it.
By their numbers in this assay, from the lowest: compound 1; then compound 3; then compounds 2 and 4 (each within the scatter of the next).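

In this assay, putting phenyl in place of (isopropylcarbonyl)oxy gives a number 9.1 percentage points higher from compound 2 to compound 4 (within the scatter), so at this saturated chain carbon a high read-out does not depend on the ester: a ring of carbon only, with no hydrogen-bond acceptors, serves within the scatter of it. The same benzyl carbamate also stands clear of the two other compounds, with a number 49.1 percentage points higher from compound 1 to compound 4 (beyond the scatter) and a number 30.7 percentage points higher from compound 3 to compound 4 (beyond the scatter), which shows that an ester-bearing group is no guarantee of a high number either, as compound 3 carries one. Nothing measured here explains why these groups differ.

Still open, on these data alone, is whether the phenyl itself matters as a ring of carbon, which a pyridine ring or a cyclohexyl ring in its place would test. An amine or a carboxylic acid on the phenyl, or a longer chain carrying it, remains equally untested in these compounds, and one concentration gives no potency for any of them.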